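The source may hold more compounds than are shown below. What is called first, only, known or untested is meant among the compounds shown, and "the series" means these compounds.

Compound 1 `CC(=O)Nc1ccc(S(=O)(=O)NNC(=O)c2cccnc2Nc2ccc(Cl)cc2)cc1` was examined in a functional assay on UACC-257 cells (Homo sapiens) for antiproliferative activity; a higher number here means that more compound is tolerated, a lower number that less compound is tolerated. In this assay compound 1 gives > 100000 nM, which is a limit of the assay rather than a measured number. Compound 2 `O=C(NNS(=O)(=O)c1ccc(F)cc1)c1cccnc1Nc1ccc(Cl)cc1Cl` likewise reaches > 100000 nM, again a limit of the assay. Among the compounds with values here, both results sit at the limit of > 100000 nM in this assay, at which 2 of the 2 values shown sit, so compound 1 stands where the only other tested compound stands, and no step between measured compounds can be read from these numbers. Compound 3 `O=C(NNS(=O)(=O)c1ccc(Cl)cc1Cl)c1cccnc1Nc1ccc(Cl)cc1` has not yet been measured. It differs from compound 1 by 2,4-dichlorophenyl in place of 4-acetamidophenyl on a sulfonyl sulfur. With both measured compounds at the limit, the data give no size or direction for this change, and the expectation is no step beyond the scatter, an estimated step that the limit leaves unreadable from compound 1 to compound 3. Compound 3 is therefore expected to fall at 150000 nM, with a range from 50000 nM to 500000 nM, most likely reported once more as a limit.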

Compound 3, concentration lethal to 50% of the cells: > 100000 nM
Compound 3 gave a limit, no number; the forecaster's own chance of this, stated with the estimate: 80%; the middle value is on the limit's open side.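

In this assay compound 3 gives > 100000 nM, again a limit of the assay and not a number. Within the data shown here, no step from compound 1 to compound 3 can be read, and the three compounds stand together: the limit of > 100000 nM in this assay, at which 3 of the 3 values shown sit. The compounds shown leave open whether any group on the sulfonyl sulfur gives a measurable value at all.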